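The source may hold more compounds than are shown below. What is called first, only, known or untested is meant among the compounds shown, and "the series" means these compounds.

Within the data shown here, in an ADME assay on microsomes from liver (Homo sapiens) for metabolic stability, read by LC-MS, with a stated time of 60 min (a higher number here means that more of the compound is left, a lower number that less of the compound is left), compound 2 `Nc1ccc(-c2ccc3ncc(-c4nnco4)c(NCCCn4ccnc4)c3c2)cc1` gives 53.7%, the higher of the two numbers so far, and compound 1 `COc1ccc(-c2ccc3ncc(-c4nnco4)c(NCCCn4ccnc4)c3c2)cc1` gives 1.68%. Compound 3 `Cc1ccc(-c2ccc3ncc(-c4nnco4)c(NCCCn4ccnc4)c3c2)cc1` differs from compound 2 by methyl in place of amino on an aromatic carbon. Among the measured compounds shown here, the only measured step at this place is a number 52 percentage points higher from compound 1 to compound 2 (beyond the scatter), large and beyond the scatter, with amino in place of methoxy. For the measured compounds named here, no measured step covers methyl, but with amino leaving, a large fall is expected in this assay. The estimated change is a number 43.7 percentage points lower from compound 2 to compound 3 (beyond the scatter). Compound 3 is estimated at 10%, with an expected range of 1% to 35%.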

Compound 3, percent of the compound remaining in the Homo sapiens assay: 0%
Estimate against measurement, compound 3: 10 percentage points above; the measured number lies below the stated range.
By their numbers in the Homo sapiens assay, from the lowest: compounds 3 and 1 (each within the scatter of the next); then compound 2.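

In the Homo sapiens assay, a number 53.7 percentage points lower from compound 2 to compound 3 (beyond the scatter), while a number 1.7 percentage points lower from compound 1 to compound 3 (within the scatter), so methyl and methoxy on this aromatic carbon cannot be told apart, and of the three groups only amino leaves a high number. The same change from amino to methyl also moves a physicochemical assay for solubility (a lower number here means a less soluble compound, a higher number a more soluble compound), where compound 2 gives 30.2 ug/mL and compound 3 gives 0.3 ug/mL: the measured solubility of compound 2, 30.2 ug/mL, and of compound 3, 0.3 ug/mL, a 100-fold lower number (2.00 log units; beyond the scatter)

Open, going by these compounds, is whether a hydroxyl or a dimethylamino group at this place would hold the number of compound 2 in the Homo sapiens assay. Also open, on these data alone, is whether the two read-outs would move together for such groups.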